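From Hydroxy to Methoxy on Compound 2

The source may report more compounds than this note shows. Statements on the series, on what has been measured and on what is new or still open speak of the compounds shown alone.

In a functional assay on HeLa cells (Homo sapiens) for antiproliferative activity, read by MTT assay, with a stated time of 48 h (on this read-out higher numbers stand for weaker inhibition of growth and lower numbers for stronger inhibition of growth), compound 1 `COc1cc(C2CC(c3ccccc3)=NN2C(=O)OCc2ccccc2)cc(OC)c1OC` gives > 10000 nM, which is a limit of the assay and not a number.

Among the compounds with values here, compound 2 `COC(=O)N1N=C(c2ccccc2)CC1c1ccc(OC)c(O)c1` gives 7520 nM, the only actual number so far in this assay.

Compound 3 `COC(=O)N1N=C(c2ccccc2)CC1c1ccc(OC)c(OC)c1` differs from compound 2 in one place: methyl in place of hydrogen on an oxygen on an aromatic ring, which turns hydroxy into methoxy.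

Within the data shown here, with no measured pair to go on, the expected step of a 1.2-fold higher number from compound 2 to compound 3 (0.08 log units; within the scatter) stays within the usual scatter in this assay.

For compound 3 the expected value is 9000 nM, with an estimated range from 3500 nM to 20000 nM.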

Compound 3, concentration for 50% growth inhibition: 5480 nM
Compound 3: middle estimate off by 1.6-fold (0.22 log units), on the high side; low and high end bracket the measured number.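

In this assay, within the data shown here, this is the first measured comparison at this position: methyl in place of hydrogen on the oxygen gives a 1.4-fold lower number from compound 2 to compound 3 (0.14 log units; within the scatter) and leaves the two compounds indistinguishable. So with this shared core, the hydrogen of the hydroxy group is not needed to keep the growth inhibition seen here. Nothing given here bears on why the two compounds read alike. Still open, on these data alone, is whether a longer chain on this oxygen, or an amine in place of the hydroxy or methoxy group, would shift the number beyond the usual scatter.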